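The source may hold more compounds than are shown below. What is called first, only, known or untested is meant among the compounds shown, and "the series" means these compounds.

Compound 1, `CC(C)(C)n1ncc(OCc2nnc(-c3ccc(Br)cc3)o2)c(Cl)c1=O`: 21400 nM
Compound 2, `CC(C)(C)n1ncc(OCc2nnc(-c3cc(F)c(Cl)cc3Cl)s2)c(Cl)c1=O`: 67100 nM
Compound 3, `CCn1ncc(OCc2nnc(-c3ccc(F)cc3)o2)c(Cl)c1=O`: > 299000 nM

All three share one core and were tested in a functional assay on the whole organism for inhibition, with Mythimna separata as the target, with a stated time of 5 days; a higher number here means that more compound is needed for the effect, a lower number that less compound is needed. Compound 1 gives 21400 nM, which is the lowest of the two plain numbers reported. Compound 2 gives 67100 nM, a higher number, and the gap between these two lies beyond the usual scatter of repeated measurements. For compound 3 the measurement reports only a limit and not a number, > 299000 nM. Compound 3 thus stands at the limit of > 299000 nM in this assay, at which 1 of the 3 values shown sits.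

The unmeasured compound 4, `CC(C)(C)n1ncc(OCc2nnc(-c3ccc(Cl)cc3)o2)c(Cl)c1=O`, differs from compound 1 in a single place: chloro in place of bromo on an aromatic carbon. Among the compounds with values here, no measured pair shows this exact exchange, so the size of the step cannot be read from the data. An exchange of one halogen for another at the same place is expected to move the number little, most likely not beyond the scatter. The expected step of a 1.2-fold higher number from compound 1 to compound 4 (0.08 log units; within the scatter) is therefore small. Compound 4 is expected to give about 26000 nM, with a likely range from 9000 nM to 80000 nM.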

Compound 4, half-maximal effective concentration: 1900 nM
Estimate against measurement, compound 4: 14-fold (1.14 log units) above; the measured number lies below the stated range.
By their numbers in this assay, from the lowest: compound 4; then compound 1; then compound 2. At a limit, above all of these: compound 3.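

Within the data shown here, until now, no two measured compounds differed in only one place, so nothing showed how much a single exchange could matter. In this assay, replacing 4-bromophenyl with 4-chlorophenyl gives an 11-fold lower number from compound 1 to compound 4 (1.05 log units; beyond the scatter), which shows that this position can respond strongly even when one halogen is exchanged for another. No measurement shown bears on why this exchange produces so large a step.

Going by these compounds, it remains open how a methoxy group or a nitrile at this same place would compare with the chloro group of compound 4. Among these compounds, with only this one pair to read, it is also open whether the same exchange would give a similar step in compounds that differ elsewhere from compound 1.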